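Swapping a Chlorophenyl for a Hydroxyphenyl on the Shared Core

The source may hold more compounds than are shown below. What is called first, only, known or untested is meant among the compounds shown, and "the series" means these compounds.

Measured compounds, in a functional assay on MCF7 cells (Homo sapiens) for antiproliferative activity, read by MTT assay, with a stated time of 72 h; on this read-out lower numbers stand for stronger inhibition and higher numbers for weaker inhibition:
Compound 1 `COc1cc(-n2cnc3ccc(-c4ccc(C(F)(F)F)cc4)cc32)cc(OC)c1OC` gives 760 nM.
Compound 2 `COc1cc(-n2cnc3ccc(-c4cc(F)ccc4F)cc32)cc(OC)c1OC` gives 6420 nM.
Compound 3 `COc1cc(-n2cnc3ccc(-c4ccccc4Cl)cc32)cc(OC)c1OC` gives > 10000 nM, which is a limit of the assay rather than a number.

Compound 3 thus stands at the limit of > 10000 nM in this assay, at which 1 of the 3 values shown sits, with no number of its own. Compound 4 `COc1cc(-n2cnc3ccc(-c4cccc(O)c4)cc32)cc(OC)c1OC` differs from it by 3-hydroxyphenyl in place of 2-chlorophenyl on an aromatic carbon. Among the measured compounds shown here, two measured steps bear on this change: an at least 13-fold higher number from compound 1 to compound 3 (1.11 log units; beyond the scatter) and an at least 1.5-fold higher number from compound 2 to compound 3 (0.19 log units; that floor lies within the scatter). Both swap one substituted phenyl for another, and the first shows such a swap can move the number a great deal. Because compound 3 sits at a limit, the step to compound 4 is expected to return a measurable number. Compound 4 is estimated at 3000 nM, within 700 nM to 15000 nM, which is expected to mean an at least 3.3-fold lower number from compound 3 to compound 4 (0.52 log units; beyond the scatter).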

Compound 4, half-maximal inhibitory concentration: 350 nM
Compound 4: the middle estimate sits 8.6-fold (0.93 log units) above what was measured; the measured number lies below the stated range.
By their numbers in this assay, from the lowest: compound 4; then compound 1; then compound 2. At a limit, above all of these: compound 3.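

In this assay, compound 4 has the lowest number of the four, and all three of its steps lie beyond the scatter: an at least 28-fold lower number from compound 3 to compound 4 (1.45 log units; beyond the scatter), an 18-fold lower number from compound 2 to compound 4 (1.26 log units; beyond the scatter) and a 2.2-fold lower number from compound 1 to compound 4 (0.34 log units; beyond the scatter). All three earlier groups at this position carry halogen, so compound 4 shows that a phenyl group bearing a hydroxyl and no halogen can give a lower number than any of them. The first step is only a floor, since compound 3 has a limit and not a number: the limit of > 10000 nM in this assay, at which 1 of the 4 values shown sits.

From the compounds shown here alone, whether an amine or a carboxylic acid in the same place on the phenyl ring would give a number as low remains open. So does whether the hydroxyl would do the same on a different carbon of that ring.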